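Swapping fluoro for amino on the chalcone-type aryl ketone

The source may report more compounds than this note shows. Statements on the series, on what has been measured and on what is new or still open speak of the compounds shown alone.

The three compounds share one core and differ only in the group on the benzoyl ring. Compound 1 `COc1ccc(-c2cc3ccccc3nc2/C=C/C(=O)c2ccc(F)cc2)cc1` gives 810 nM in a functional assay on SK-BR-3 cells (Homo sapiens) for antiproliferative activity, read by XTT assay, with a stated time of 72 h (on this read-out higher numbers stand for weaker inhibition and lower numbers for stronger inhibition), the lowest of the three numbers; compound 2 `COc1ccc(-c2cc3ccccc3nc2/C=C/C(=O)c2ccc(O)cc2)cc1` gives 3880 nM and compound 3 `COc1ccc(C(=O)/C=C/c2nc3ccccc3cc2-c2ccc(OC)cc2)cc1` gives 9280 nM. Replacing fluoro with hydroxy weakened inhibition a 4.8-fold higher number from compound 1 to compound 2 (0.68 log units; beyond the scatter), and replacing it with methoxy weakened it further an 11-fold higher number from compound 1 to compound 3 (1.06 log units; beyond the scatter). Compound 4 `COc1ccc(-c2cc3ccccc3nc2/C=C/C(=O)c2ccc(N)cc2)cc1` differs from compound 1 as follows: amino in place of fluoro on an aromatic carbon. Like hydroxy, amino brings a hydrogen-bond donor and acceptor where fluoro had none, so a weakening step of similar size is expected a 4.3-fold higher number from compound 1 to compound 4 (0.64 log units; beyond the scatter). Compound 4 is therefore estimated at 3500 nM, with a range of 1200 nM to 10000 nM.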

Compound 4, half-maximal inhibitory concentration: 8560 nM
Compound 4: middle estimate off by 2.4-fold (0.39 log units), on the low side; low and high end bracket the measured number.
By their numbers in this assay, from the lowest: compound 1; then compound 2; then compounds 4 and 3 (each within the scatter of the next).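

At this position, fluoro stands apart from amino as well: an 11-fold higher number from compound 1 to compound 4 (1.02 log units; beyond the scatter) is a large step in the same direction as methoxy. Amino and hydroxy are not interchangeable here, with a 2.2-fold higher number from compound 2 to compound 4 (0.34 log units; beyond the scatter), while amino and methoxy cannot be told apart, with a 1.1-fold lower number from compound 3 to compound 4 (0.04 log units; within the scatter). Nothing shown here explains these differences.

As far as these compounds go, whether another halogen such as chloro, or a small carbon group such as methyl, would keep the number near that of compound 1 remains open. So does the effect of a carboxylic acid in the same place.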